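The source may hold more compounds than are shown below. What is called first, only, known or untested is meant among the compounds shown, and "the series" means these compounds.

Working notes on the series.

Compound 1 `Sc1ncnc2c(Cc3ccccc3)ncn12` and compound 2 `Cc1ccc(Cc2ncn3c(S)ncnc23)cc1` share one core. In a functional assay on CCRF-CEM cells (Homo sapiens) for cytotoxicity (on this read-out higher numbers stand for lower toxicity in this test and lower numbers for higher toxicity in this test), compound 1 gives 35100 nM and compound 2 gives 32800 nM. The change between them is methyl in place of hydrogen on an aromatic carbon and the step it made is a 1.1-fold lower number from compound 1 to compound 2 (0.03 log units; within the scatter).

Compound 3 `Cc1ncn2c(=O)[nH]c(=S)[nH]c12` has a different core; the difference between the two cores is not broken down here. In this assay compound 3 gives 786000 nM, the highest number of the three measured compounds, with the step to compound 1 and the step to compound 2 both beyond the scatter.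

Compound 4 `Cc1nc(C)n2c(=O)[nH]c(=S)[nH]c12` is compound 3 with methyl in place of hydrogen on an aromatic carbon. Among the measured compounds shown here, this is the same kind of change as the one from compound 1 to compound 2, but not the same: there the methyl entered on a six-membered aromatic ring of carbon only, para to a large group, whereas here it enters on a five-membered aromatic ring with 2 nitrogen, part of a fused system of two rings, between two ring nitrogen atoms, two ring bonds from the ring atom that bears a methyl group.

For the measured compounds named here, the expectation for compound 4 rests on the only comparable change measured, the step from compound 1 to compound 2 of a 1.1-fold lower number from compound 1 to compound 2 (0.03 log units; within the scatter), which lay within the scatter. The step from compound 3 to compound 4 in this assay is therefore expected to be a 1.1-fold lower number from compound 3 to compound 4 (0.05 log units; within the scatter). Compound 4 is estimated at 700000 nM, with a range from 300000 nM to 1600000 nM.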

Compound 4, half-maximal cytotoxic concentration: 526000 nM
For compound 4 the middle estimate is 1.3-fold (0.12 log units) above the measured one, and the stated range covers the measured number.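

The new step in this assay is a 1.5-fold lower number from compound 3 to compound 4 (0.17 log units; within the scatter), so on the core of compound 3, methyl in place of hydrogen on an aromatic carbon gives no reading that can be told apart from the scatter. Set beside the earlier step, the change carries from one core to the other with no difference that can be read, and the two steps agree as far as this test can show: the same change on two cores in this assay, a 1.1-fold lower number (0.03 log units; within the scatter) from compound 1 to compound 2 and a 1.5-fold lower number (0.17 log units; within the scatter) from compound 3 to compound 4, 1.4-fold (0.15 log units) apart, within the scatter of two such steps. Among the compounds shown here, this does not show that methyl is without effect in general or that the agreement extends further, as the series offers only two such pairs, the methyl stands at a different kind of place on each core, and neither step alone departs from the scatter.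

Still open, going by these compounds, is whether a longer chain such as ethyl or propyl, on the aromatic carbon of the five-membered ring of compound 3, would give a step beyond the scatter, and whether that step would match one on the core of compound 1. Equally open, on these data alone, is how an amine or a carboxylic acid at these same places would read, since a group of that kind differs from methyl in more than size alone.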